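Replacing the carboxyphenyl group of compound 1

The source may report more compounds than this note shows. Statements on the series, on what has been measured and on what is new or still open speak of the compounds shown alone.

In an ADME assay (liver) for metabolic stability, with Liver microsome (Rattus norvegicus) as the target, read by LC-MS, using microsomes and NADPH, with stated times of 5 min and 60 min, tested at 4 uM (on this read-out lower numbers stand for a less stable compound and higher numbers for a more stable compound), compound 1 `Cc1c(OCCCCOc2ccc(C(=O)O)cc2F)ccc(C(=O)CC2CCCC2)c1O` gives 66%, level with compound 3 `Cc1c(OCCCCOc2ccc(C(=O)O)cc2)ccc(C(=O)CC(C)C)c1O` at 66%, and compound 2 `Cc1c(OCCCCOc2ccc(C(=O)O)cc2F)ccc(C(=O)CC(C)C)c1O` gives 57%, within the scatter of both. The next compound, compound 4 `Cc1c(OCCCCOc2ccc(C(=O)O)c(Cl)c2)ccc(C(=O)CC2CCCC2)c1O`, has 4-carboxy-3-chlorophenyl in place of 4-carboxy-2-fluorophenyl on an oxygen on a saturated carbon.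

Within the data shown here, two measured steps bear on this change. The closer one is hydrogen in place of fluoro on an aromatic carbon, a number 9 percentage points higher from compound 2 to compound 3 (within the scatter). The other lies at the far end of the molecule, isopropyl in place of cyclopentyl, a number 9 percentage points lower from compound 1 to compound 2 (within the scatter). Among the measured compounds shown here, neither step exceeds the scatter, but no chloro compound has been measured yet, so the evidence for this replacement is indirect and the range stays wide. No step beyond the scatter is expected in this assay, and the expected change is small: a number 4 percentage points lower from compound 1 to compound 4 (within the scatter). The estimate for compound 4 is 62%, with an expected range of 47% to 77%.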

Compound 4, percent of the compound remaining: 67%
Estimate against measurement, compound 4: 5 percentage points below, within the range that was stated.
By their numbers in this assay, from the lowest: compounds 2, 1, 3 and 4 (each within the scatter of the next).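

In this assay, 4-carboxy-3-chlorophenyl in place of 4-carboxy-2-fluorophenyl on an oxygen on a saturated carbon gives a number 1 percentage points higher from compound 1 to compound 4 (within the scatter), so the chloro replacement now has a direct reading with the cyclopentyl group retained. The only other listed change on this aryl group, hydrogen in place of fluoro with the isopropyl group retained, gives a number 9 percentage points higher from compound 2 to compound 3 (within the scatter), so neither change at this position exceeds the scatter. No supporting measurement bears on why the read-out stays within the scatter for this replacement. On these data alone, whether 4-carboxy-3-chlorophenyl gives a similar result with isopropyl in place of cyclopentyl remains open. Also open, as far as these compounds go, is how this assay responds to a methoxy group or a nitrile on the ring, or to a tetrazole in place of the carboxylic acid.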